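A few compounds are considered here, and "the series" means these few. Any claim that something is new, unique, unknown or untested is made for them only; others in the source may bear on it.

Measured compounds: compound 1, `Fc1cc(C(F)(F)F)ccc1Nc1nc2nonc2nc1Nc1ccc(C(F)(F)F)cc1F`, < 1000 nM; compound 2, `C1CCC(Nc2nc3nonc3nc2NC2CCCC2)C1`, 45000 nM; compound 3, `Fc1ccccc1Nc1nc2nonc2nc1NC1CCCCC1`, 13400 nM.

The read-out is an assay on mitochondria from L6 cells (Rattus norvegicus) for activation, with a stated time of 90 min; on this read-out higher numbers stand for an effect only at larger amounts of compound and lower numbers for an effect already at smaller amounts. For compound 1 this assay reports only a limit, < 1000 nM, not a number. Compound 2 gives 45000 nM in this assay, and compound 3 gives 13400 nM, the lowest of the two numbers shown; the gap from compound 3 up to compound 2 lies beyond the scatter. The limit of compound 1 sits elsewhere (the limit of < 1000 nM in this assay, at which 1 of the 3 values shown sits).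

Compound 4, `Cc1ccccc1Nc1nc2nonc2nc1Nc1ccccc1F`, has not been measured. It differs from compound 3 in one place: 2-methylphenyl in place of cyclohexyl on a nitrogen on an aromatic ring. With this change compound 4 carries two aryl groups on the shared core, as compound 1 does, whereas compound 2 carries none and compound 3 one. Because compound 1 sits at < 1000 nM and compound 3 at 13400 nM, compound 4 is expected to give a lower number than compound 3, a step of a 5.4-fold lower number from compound 3 to compound 4 (0.73 log units; beyond the scatter) beyond the scatter. The estimate for compound 4 in this assay is 2500 nM, within 600 nM to 10000 nM.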

Compound 4, half-maximal effective concentration: 1100 nM
The estimate for compound 4 lay 2.3-fold (0.36 log units) above the measured number; measured number inside the range.
By their numbers in this assay, from the lowest: compound 4; then compound 3; then compound 2. At a limit, below all of these: compound 1.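

In this assay, the change from cyclohexylamino to (2-methylphenyl)amino gives a 12-fold lower number from compound 3 to compound 4 (1.09 log units; beyond the scatter), the first step shown between compounds that differ in one place. For the compounds shown here, the earlier compounds differed in more than one place, so they could not tie a difference to this nitrogen alone; here, the single exchange of cyclohexyl for 2-methylphenyl goes with a large step. Compound 1 remains a limit and not a number: the limit of < 1000 nM in this assay, at which 1 of the 4 values shown sits.

The compounds shown do not separate the contribution of the aromatic ring from that of its methyl group, since a plain phenyl group does not appear at this nitrogen. From the compounds shown here alone, how a pyridine ring, a longer alkyl chain or a phenyl ring carrying a carboxylic acid would behave at the same place also remains open.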